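Ethyl to Cyclopropyl on an Aromatic Oxygen: What to Expect

The source may report more compounds than this note shows. Statements on the series, on what has been measured and on what is new or still open speak of the compounds shown alone.

Of the compounds shown here, two have been measured in a functional assay on cells for positive allosteric modulation of G-protein coupled receptor 68 (Homo sapiens), read by a luciferase reporter and cAMP accumulation, with a stated time of 30 min, at pH 6.8 and pH 8.3, in the presence of a further agent that is not named here; on this read-out lower numbers stand for lower potency and higher numbers for higher potency (the scale is a negative logarithm). Compound 1 `Nc1nc(NCc2ccc(C(F)(F)F)cc2)nc(-c2ccccc2CO)n1` gives 5.03. Compound 2 `CCOc1ccc(CNc2nc(N)nc(-c3ccccc3CO)n2)cc1` gives 4.77 in this assay. For the measured compounds named here, the single measured step, a number 0.26 log units lower from compound 1 to compound 2 (within the scatter), puts ethoxy in place of trifluoromethyl on an aromatic carbon and lies within the scatter, so the numbers of compound 2 and compound 1 cannot be told apart; compound 2 simply sits alongside compound 1.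

Compound 3 `Nc1nc(NCc2ccc(OC3CC3)cc2)nc(-c2ccccc2CO)n1` differs from compound 2 by cyclopropyl in place of ethyl on an oxygen on an aromatic ring. Going by the values given here, no measured step touches this oxygen; the one step known, a number 0.26 log units lower from compound 1 to compound 2 (within the scatter), concerns another group and was small. With nothing bearing directly on the change, the step in this assay from compound 2 to compound 3 is expected to stay within the scatter, that is a number 0.03 log units higher from compound 2 to compound 3 (within the scatter). Compound 3 is therefore estimated at 4.8, with a range from 4.4 to 5.3.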

Compound 3, negative logarithm of the antagonist equilibrium constant: 5.07
The estimate for compound 3 lay 0.27 log units below the measured number, within the range that was stated.
By their numbers in this assay, from the lowest: compounds 2, 1 and 3 (each within the scatter of the next).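

In this assay, the oxygen on the aromatic ring now has a measured step of its own: cyclopropyl in place of ethyl, which brings in a three-membered ring, gives a number 0.30 log units higher from compound 2 to compound 3 (within the scatter). This place therefore takes that small ring with no change that can be told from the scatter, and the same holds for cyclopropyloxy in place of trifluoromethyl on the aromatic carbon, with a number 0.04 log units higher from compound 1 to compound 3 (within the scatter). Trifluoromethyl, ethoxy and cyclopropyloxy cannot be separated by these numbers, and no other measurement is available here to help interpret them.

Going by these compounds, whether an amine or a carboxylic acid at this place would move the number beyond the scatter remains open. So does the effect of a longer chain on the oxygen, such as butyl.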